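Spiro-piperidine amides: piperidine amide variation and cholesterol-transporter binding

The source may report more compounds than this note shows. Statements on the series, on what has been measured and on what is new or still open speak of the compounds shown alone.

Measured compounds in an assay on HEK293 cells for displacement of a labelled ligand from NPC1-like intracellular cholesterol transporter 1 (Homo sapiens); a lower number here means a stronger inhibitor, a higher number a weaker inhibitor:
- compound 1 `CC(C)(C)c1ccc(C(=O)N2CCC3(CC2)C(=O)N(CC(=O)N2CCC(CCO)CC2)CN3c2ccccc2)cc1` gives 2600 nM
- compound 2 `CC(C)(C)c1ccc(C(=O)N2CCC3(CC2)C(=O)N(CC(=O)N2CCCC(O)C2)CN3c2ccccc2)cc1` gives 12200 nM
- compound 3 `CCOC(=O)C1CCN(C(=O)CN2CN(c3ccccc3)C3(CCN(C(=O)c4ccc(C(C)(C)C)cc4)CC3)C2=O)CC1` gives 3100 nM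

Compound 3 stands second highest of the three numbers in this assay. Its nearest neighbour is compound 1, and the gap a 1.2-fold higher number from compound 1 to compound 3 (0.08 log units; within the scatter) lies within the scatter, so no order between compound 1 and compound 3 can be stated. Compound 2 is furthest away: a 3.9-fold lower number from compound 2 to compound 3 (0.59 log units; beyond the scatter).

The next compound is compound 4 `CC(C)(C)c1ccc(C(=O)N2CCC3(CC2)C(=O)N(CC(=O)N2CCCC(C(N)=O)C2)CN3c2ccccc2)cc1`. The change from compound 3 is 3-carbamoylpiperidin-1-yl in place of 4-(ethoxycarbonyl)piperidin-1-yl on a carbonyl carbon.

Among the compounds with values here, two measured steps bear on this. The step of a 3.9-fold lower number from compound 2 to compound 3 (0.59 log units; beyond the scatter) shows the gain when the 3-hydroxypiperidin-1-yl ring of compound 2 is replaced by the 4-(ethoxycarbonyl)piperidin-1-yl ring of compound 3, and the step of a 4.7-fold higher number from compound 1 to compound 2 (0.67 log units; beyond the scatter) shows the loss on going to that 3-hydroxypiperidin-1-yl ring from compound 1. Compound 4 carries a 3-carbamoylpiperidin-1-yl ring, named in the manner of the ring of compound 2 rather than that of compound 3, and with one hydrogen-bond donor, as in compound 2. The direction in this assay is therefore expected to be towards a higher number, with a step of about the size seen in compound 2: a 2.9-fold higher number from compound 3 to compound 4 (0.46 log units; beyond the scatter) is the expected change. For compound 4 the expected value is 9000 nM, with a range from 3500 nM to 25000 nM.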

Compound 4, half-maximal inhibitory concentration: 16900 nM
The estimate for compound 4 lay 1.9-fold (0.27 log units) below the measured number; the measured number falls inside the stated range.
By their numbers in this assay, from the lowest: compounds 1 and 3 (each within the scatter of the next); then compounds 2 and 4 (each within the scatter of the next).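

In this assay, swapping hydroxy for carbamoyl on a saturated ring carbon gives no order, since a 1.4-fold higher number from compound 2 to compound 4 (0.14 log units; within the scatter) lies within the scatter, so the 3-carbamoylpiperidin-1-yl and 3-hydroxypiperidin-1-yl rings cannot be told apart. The 3-carbamoylpiperidin-1-yl ring loses ground against both the 4-(ethoxycarbonyl)piperidin-1-yl and the 4-(2-hydroxyethyl)piperidin-1-yl rings, with a 5.5-fold higher number from compound 3 to compound 4 (0.74 log units; beyond the scatter) and a 6.5-fold higher number from compound 1 to compound 4 (0.81 log units; beyond the scatter). The four compounds thus fall into two groups, with compounds 2 and 4 at higher numbers than compounds 1 and 3 and no compound going against this, but no measurement at hand gives a cause for the split.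

Every step across the split changes both the group and its place on the piperidine ring, so the two effects remain tied together; a 4-carbamoylpiperidin-1-yl ring or a 3-(ethoxycarbonyl)piperidin-1-yl ring would separate them. Also open, from the compounds shown here alone, is whether a carboxylic acid or an amine on the piperidine ring would follow the same split.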